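The compounds below may be only part of what the source reports. "The series", "measured", "known", "first", "only" and "open" are said of these compounds alone.

Compound 1 `CC(C)c1ccc(-c2nc(CN3CCCC3)nn2C)cc1`: 1000 nM
Compound 2 `Cn1nc(CN2CCCC2)nc1-c1ccc2ccsc2c1`: > 1000 nM

In an assay on membranes from Jurkat cells for displacement of a labelled ligand from Sigma intracellular receptor 2 (Homo sapiens), read by scintillation counting, with a stated time of 1 h (a lower number here means a stronger inhibitor, a higher number a weaker inhibitor), compound 1 gives 1000 nM, the only actual number among the two results shown. For compound 2 the assay reports no number but a limit, > 1000 nM, which is the limit of > 1000 nM in this assay, at which 1 of the 2 values shown sits. Compound 3 `Cn1nc(CN2CCCC2)nc1-c1ccc(C2(C(F)(F)F)CC2)cc1` is not yet measured; it differs from compound 1 by 1-(trifluoromethyl)cyclopropyl in place of isopropyl on an aromatic carbon. Among the compounds with values here, with no measured step of this kind to lean on, the step expected is a 1.5-fold higher number from compound 1 to compound 3 (0.18 log units; within the scatter), small and either within the scatter or slightly toward weaker binding. Compound 3 is therefore estimated at 1500 nM, with a range from 400 nM to 6000 nM.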

Compound 3, inhibition constant: > 1000 nM
Compound 3 ended at the assay's limit; the forecaster's own chance of this, stated with the estimate: 50%; the middle value lies beyond the limit too.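

On the aromatic carbon para to a large group, 1-(trifluoromethyl)cyclopropyl in place of isopropyl gives a number no lower from compound 1 to compound 3 (the limit leaves the size open). Compound 3 reads > 1000 nM, which is a limit and not a number, so this larger group brought no measurable gain. Ranking among these compounds is now largely hidden: the limit of > 1000 nM in this assay, at which 2 of the 3 values shown sit.

On these data alone, whether the true number for compound 3 lies close to that of compound 1 or far from it stays open. So does how a methoxy group, an amine or a single fluorine atom would read at this position.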